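The source may report more compounds than this note shows. Statements on the series, on what has been measured and on what is new or still open speak of the compounds shown alone.

Measured so far in an assay on cells with Cystic fibrosis transmembrane conductance regulator variant F508del (Homo sapiens) as the target, read by voltage clamp, with a stated time of 24 h, in the presence of a further agent that is not named here; a lower number here means that less compound is needed, a higher number that more compound is needed for the effect:
compound 1 `COc1ncc(C(F)(F)F)cc1CO[C@H]1[C@H](C(C)(C)C)[C@@H](C(=O)O)N(C(=O)[C@@H]2CCCCO2)[C@H]1c1ccccc1` – 213 nM
compound 2 `COc1ncc(C(F)(F)F)cc1CO[C@H]1[C@H](C(C)(C)C)[C@@H](C(=O)O)N(C(=O)[C@H]2CCCCO2)[C@H]1c1ccccc1` – 346 nM

Within the data shown here, compound 1 and compound 2 lie within the scatter of each other in this assay, the step of a 1.6-fold higher number from compound 1 to compound 2 (0.21 log units; within the scatter) being the only measured step, and it rests solely on (the fact that compounds 1 and 2 differ only in the configuration as drawn). Compound 3 `CCc1ccccc1[C@H]1[C@@H](OCc2cc(C(F)(F)F)cnc2OC)[C@H](C(C)(C)C)[C@@H](C(=O)O)N1C(=O)[C@@H]1CCCCO1` is compound 1 with ethyl in place of hydrogen on an aromatic carbon, read one bond further out as phenyl to 2-ethylphenyl. Among the measured compounds shown here, no measured step touches a substituent on that six-membered aromatic ring of carbon only; the single step from compound 1 to compound 2 concerns a saturated ring carbon and stayed within the scatter, so it gives no direction for this change. With nothing to pull either way, the expectation for compound 3 in this assay is a number close to that of compound 1, the step of a 1.2-fold higher number from compound 1 to compound 3 (0.07 log units; within the scatter) not expected to exceed the scatter. Estimate for compound 3: 250 nM, range 80 nM to 800 nM.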

Compound 3, half-maximal effective concentration: 48 nM
Beside the measured number, compound 3's estimate is 5.2-fold (0.72 log units) above it, and the stated range ends above it.
By their numbers in this assay, from the lowest: compound 3; then compounds 1 and 2 (each within the scatter of the next).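

Ethyl in place of hydrogen on an aromatic carbon, ortho to a large group, gives a 4.4-fold lower number from compound 1 to compound 3 (0.65 log units; beyond the scatter) in this assay, the first measured step in the series beyond the scatter. This place on the six-membered aromatic ring of carbon only therefore responds to substitution, with less compound needed for the effect, and the earlier step at a saturated ring carbon gave no sign of this. Nothing measured here bears on why this change lowers the number.

The compounds shown leave open whether methyl, methoxy or a longer chain such as propyl at this place would read like ethyl, and whether ethyl on another carbon of that ring would do the same. Also open, going by these compounds, is whether ethyl would give a similar step on compound 2.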